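This account rests on a few compounds, and the source may have more. Where it says the series, first, only, none or still open, it means among the compounds named here.

Working notes on the series. Within the data shown here, compound 1 `CN(Cc1nc(C2CCN(Cc3ccccc3F)CC2)no1)c1ncc(C(=O)NO)cn1` stands highest of the two numbers so far: in a functional assay on Raji cells (Homo sapiens) for antiproliferative activity, read by MTT assay, with a stated time of 72 h (on this read-out lower numbers stand for stronger inhibition and higher numbers for weaker inhibition), compound 1 gives 98.6 nM, while compound 2 `CN(Cc1nc(C2CCN(Cc3ccc(F)cc3)CC2)no1)c1ncc(C(=O)NO)cn1` gives 22 nM. Among the measured compounds shown here, the one measured step, a 4.5-fold lower number from compound 1 to compound 2 (0.65 log units; beyond the scatter), is the only reference for this part of the molecule. Compound 3 `CN(Cc1nc(C2CCN(Cc3ccc(F)cc3Cl)CC2)no1)c1ncc(C(=O)NO)cn1` carries 2-chloro-4-fluorophenyl in place of 2-fluorophenyl on a saturated chain carbon bound to an amine nitrogen in a ring, so it keeps a halogen where compound 1 has its fluorine and adds the fluorine that compound 2 carries. A drop is expected in this assay, smaller than that of compound 2, since the change only partly matches it; the estimated step is a 2.2-fold lower number from compound 1 to compound 3 (0.34 log units; beyond the scatter). Compound 3 is expected near 45 nM, with a range of 15 nM to 140 nM.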

Compound 3, half-maximal inhibitory concentration: 116 nM
Estimate against measurement, compound 3: 2.6-fold (0.41 log units) below; the range from low to high includes it.
By their numbers in this assay, from the lowest: compound 2; then compounds 1 and 3 (each within the scatter of the next).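

In this assay, 2-chloro-4-fluorophenyl does not separate from 2-fluorophenyl (a 1.2-fold higher number from compound 1 to compound 3 (0.07 log units; within the scatter)), so the 4-fluoro group present in compound 3 brings no measurable gain here. Chloro in place of hydrogen on an aromatic carbon instead removes the advantage held by compound 2 (a 5.3-fold higher number from compound 2 to compound 3 (0.72 log units; beyond the scatter)), which shows that the benefit of 4-fluorophenyl depends on the rest of the ring. Nothing at hand explains this result.

The compounds shown leave open how 2-chlorophenyl alone or 4-chlorophenyl would stand at this place. Unsubstituted phenyl and 4-methoxyphenyl also remain open as comparisons.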